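A few compounds are considered here, and "the series" means these few. Any claim that something is new, unique, unknown or untested is made for them only; others in the source may bear on it.

In a toxicity assay on HepG2 cells (Homo sapiens) for inhibition, read by CellTiter-Glo, with a stated time of 48 h (a higher number here means a weaker inhibitor, a lower number a stronger inhibitor), compound 1 `COc1ccc2nc(C)cc(OCC(=O)Nc3cc(C)cc(C)c3)c2c1` gives 20000 nM and compound 3 `COc1ccc2nc(C)cc(OCC(=O)Nc3ccc(Br)c(C)c3)c2c1` gives 15900 nM. Compound 2 `Cc1cc(C)cc(NC(=O)COc2cc(C)nc3ccc(OC(F)(F)F)cc23)c1` reaches only the limit > 100000 nM in this assay. The step of an at least 5.0-fold higher number from compound 1 to compound 2 (0.69 log units; beyond the scatter) is at least modest, whereas the step of a 1.3-fold lower number from compound 1 to compound 3 (0.10 log units; within the scatter) lies within the scatter. Compound 3 thus stands with compound 1 among the two numbers shown, within the scatter of it, the third value being a limit. Compound 4 `COc1ccc2nc(C)cc(OCC(=O)Nc3cc(C)nc(C)n3)c2c1` differs from compound 3 by 2,6-dimethylpyrimidin-4-yl in place of 4-bromo-3-methylphenyl on an amide-type nitrogen. For the measured compounds named here, only the swap of the ring on the amide-type nitrogen between compound 1 and compound 3 touches the same place, and it was within the scatter; no measured step brings in a ring with hetero atoms. The expected step of a 1.6-fold higher number from compound 3 to compound 4 (0.20 log units; within the scatter) is therefore small, leaning toward a higher number. Compound 4 is estimated at 25000 nM, in a range from 8000 nM to 100000 nM.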

Compound 4, half-maximal inhibitory concentration: > 100000 nM
Compound 4: a limit, no number; the forecaster's own chance of this, stated with the estimate: 30%; middle value at least 4.0-fold (0.60 log units) from the limit.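

In this assay, 2,6-dimethylpyrimidin-4-yl on the amide-type nitrogen gives an at least 6.2-fold higher number from compound 3 to compound 4 (0.79 log units; beyond the scatter) and an at least 5.0-fold higher number from compound 1 to compound 4 (0.69 log units; beyond the scatter), whereas the earlier swap there, between rings of carbon only, gave a 1.3-fold lower number from compound 1 to compound 3 (0.10 log units; within the scatter). For the compounds shown here, this place therefore responds to a ring with hetero atoms, a change no earlier compound carried there. The value of compound 4 is a limit, so both new steps are bounds only: the limit of > 100000 nM in this assay, at which 2 of the 4 values shown sit.

Open, on these data alone, is whether a pyridine ring on the amide-type nitrogen would still give a number rather than a limit. Also open, as far as these compounds go, is whether an unsubstituted pyrimidine ring would behave like 2,6-dimethylpyrimidin-4-yl.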